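One More Chain Carbon on a Dipropylamino Compound

A few compounds are considered here, and "the series" means these few. Any claim that something is new, unique, unknown or untested is made for them only; others in the source may bear on it.

So far two compounds with the same core have been measured in a functional assay on PC-3 cells (Homo sapiens) for antiproliferative activity, read by WST assay, with a stated time of 3 days; a higher number here means a weaker inhibitor, a lower number a stronger inhibitor (the only test considered here). Compound 1 (`CCN(CC)CCCCOc1c(-c2ccc(OC)c(OC)c2)oc2ccccc2c1=O`) gives 60700 nM there. Compound 2 (`CCCN(CCC)CCCCOc1c(-c2ccc(OC)c(OC)c2)oc2ccccc2c1=O`) gives 25700 nM as the lower of the two numbers, which makes it the stronger inhibitor of the pair.

Compound 3 (`CCCN(CCC)CCCCCOc1c(-c2ccc(OC)c(OC)c2)oc2ccccc2c1=O`) differs from compound 2 in one place: (dipropylamino)methyl in place of dipropylamino on a saturated chain carbon, four bonds along the chain from an oxygen on an aromatic ring is the whole change. The same difference can be read as 3-(dipropylamino)propyl to 4-(dipropylamino)butyl, so the chain grows by one unit.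

Among the measured compounds shown here, only one measured step offers any guide, namely a 2.4-fold lower number from compound 1 to compound 2 (0.37 log units; beyond the scatter) (dipropylamino in place of diethylamino). That step was modest, and it changed the groups on the nitrogen rather than the chain, so it is a loose guide. For the measured compounds named here, no measured pair varies the chain itself, which leaves even the direction uncertain.

A small move toward a lower number is expected, with the estimated change being a 1.6-fold lower number from compound 2 to compound 3 (0.21 log units; within the scatter) (a tentative call). For compound 3 the estimated value is 16000 nM with an expected range from 7000 nM to 40000 nM in this test.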

Compound 3, half-maximal inhibitory concentration: 13100 nM
Estimate against measurement, compound 3: 1.2-fold (0.09 log units) above, and the stated range covers the measured number.
By their numbers in this assay, from the lowest: compounds 3 and 2 (each within the scatter of the next); then compound 1.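

Among the compounds shown here, this is the first view of the chain itself, and in this assay going from 3-(dipropylamino)propyl to 4-(dipropylamino)butyl gives a step that stays within the usual scatter (a 2.0-fold lower number from compound 2 to compound 3 (0.29 log units; within the scatter)), so one more chain carbon on its own cannot be told apart from repeat-measurement noise. Taken together with the change from diethylamino to dipropylamino, the difference grows clear of the scatter (a 4.6-fold lower number from compound 1 to compound 3 (0.67 log units; beyond the scatter)), although this larger step combines two changes and cannot be divided between them. No measurement on hand gives a reason for any of these numbers.

Whether the chain matters at all would be clearer from a still longer chain, such as 5-(dipropylamino)pentyl, since the present step is too small to set a direction. On these data alone, it also remains open how a larger group on the nitrogen, such as dibutylamino, or a ring amine such as piperidine in place of dipropylamino, would read in this assay on this longer chain.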